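Chain extension on the triazole nitrogen of a thioamide series

The compounds below may be only part of what the source reports. "The series", "measured", "known", "first", "only" and "open" are said of these compounds alone.

Measured so far:
compound 1 `CN1C(=S)[C@@H](NC(=O)c2nc(Cc3ccccc3)n(C)n2)COc2ccccc21` — 2.5 nM
compound 2 `CCCCCn1nc(C(=O)N[C@H]2COc3ccccc3N(C)C2=S)nc1Cc1ccccc1` — 805 nM

In a functional assay on HT-29 cells (Homo sapiens) for inhibition, read by luminescence and CellTiter-Glo, with a stated time of 24 h (on this read-out higher numbers stand for an effect only at larger amounts of compound and lower numbers for an effect already at smaller amounts), compound 1 gives the lowest of the two numbers; compound 2 sits a 320-fold higher number from compound 1 to compound 2 (2.51 log units; beyond the scatter) away. Compound 3 `CN1C(=S)[C@@H](NC(=O)c2nc(Cc3ccccc3)n(CCCCCC#N)n2)COc2ccccc21` differs from compound 1 by 4-cyanobutyl in place of hydrogen on a saturated chain carbon bound to an aromatic nitrogen. Within the data shown here, the one step that bears on it, a 320-fold higher number from compound 1 to compound 2 (2.51 log units; beyond the scatter), is large and runs toward higher numbers, with a chain of comparable length entering at the same place. Among the measured compounds shown here, a step of similar direction and size is therefore expected for compound 3, a 160-fold higher number from compound 1 to compound 3 (2.20 log units; beyond the scatter), with some uncertainty since the nitrile-bearing chain has no measured counterpart. Compound 3 is estimated at 400 nM, within 80 nM to 2500 nM.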

Compound 3, half-maximal effective concentration: 3830 nM
Estimate against measurement, compound 3: 9.6-fold (0.98 log units) below; measured number above the stated range.
By their numbers in this assay, from the lowest: compound 1; then compound 2; then compound 3.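

In this assay this position tolerates a long chain even less well than compound 2 indicated, with the nitrile-ended chain lying far from the methyl of compound 1 (a 1500-fold higher number from compound 1 to compound 3 (3.19 log units; beyond the scatter)). The chain end also matters, not chain length alone, since adding the nitrile to the plain chain gives a further, modest shift (a 4.8-fold higher number from compound 2 to compound 3 (0.68 log units; beyond the scatter)). Nothing available here speaks to the reason for these shifts.

Still open, on these data alone, is how an ethyl or propyl chain at this position compares with the methyl. Also open, as far as these compounds go, is whether an amine or a carboxylic acid at the chain end moves the number in the same direction as the nitrile.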